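This account rests on a few compounds, and the source may have more. Where it says the series, first, only, none or still open, it means among the compounds named here.

Measured compounds:
- compound 1, `CN(C[C@H]1Cc2c(cccc2N2C[C@H]3CNC[C@H]3C2)CN1)[C@H]1CCCc2cccnc21`: 54.7%
- compound 2, `CN(C)[C@H]1CCN(c2cccc3c2C[C@H](CN(C)[C@H]2CCCc4cccnc42)NC3)C1`: 18.5%

In an ADME assay on microsomes from liver (Mus musculus) for metabolic stability, using NADPH, with a stated time of 10 min (a higher number here means that more of the compound is left, a lower number that less of the compound is left), compound 1 gives 54.7%, the higher of the two measured numbers; compound 2 comes next, with a number 36.2 percentage points lower from compound 1 to compound 2 (beyond the scatter). That single measured step concerns a change of a different kind than the one examined here.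

Compound 3, `CN1CC[C@H]2CN(c3cccc4c3C[C@H](CN(C)[C@H]3CCCc5cccnc53)NC4)C[C@H]21`, differs from compound 1 by a group of 9 heavy atoms (7 carbon, 2 nitrogen; 2 five-membered non-aromatic rings with 1 hetero atom each) in place of a group of 8 heavy atoms (6 carbon, 2 nitrogen; 2 five-membered non-aromatic rings with 1 hetero atom each), on an aromatic carbon. No measured step follows this particular change, so no direct guide exists; the one step shown, a number 36.2 percentage points lower from compound 1 to compound 2 (beyond the scatter), shows only that alterations at this aromatic carbon can move this assay widely.

Compound 3 is therefore expected to land with a number 9.7 percentage points lower from compound 1 to compound 3 (within the scatter), a step that need not reach beyond the scatter. The estimate for compound 3 in this assay is 45%, with a range from 20% to 70%.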

Compound 3, percent of the compound remaining: 24%
For compound 3 the middle estimate is 21 percentage points above the measured one; the range from low to high includes it.
By their numbers in this assay, from the lowest: compounds 2 and 3 (each within the scatter of the next); then compound 1.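

In this assay, the methyl-bearing group at this aromatic carbon gives a number 30.7 percentage points lower from compound 1 to compound 3 (beyond the scatter), so keeping both five-membered rings, as compound 3 does, is not enough to hold the number of compound 1. The comparison between the two changed groups gives a number 5.5 percentage points higher from compound 2 to compound 3 (within the scatter), which means that a group with one five-membered ring and a group with two such rings read alike here, and both stand well apart from compound 1. No measured evidence accounts for this result.

The compounds shown leave open whether the fall in compound 3 follows the added carbon or the lost hydrogen-bond donor. They also leave open how an acetyl group or a longer chain such as ethyl would read in the place of that methyl.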